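Thioether series: from 3-bromobenzyl to allyl

The compounds below may be only part of what the source reports. "The series", "measured", "known", "first", "only" and "open" are said of these compounds alone.

Values in a functional assay on MGC-803 cells (Homo sapiens) for inhibition, read by MTT assay, with a stated time of 72 h; a lower number here means a stronger inhibitor, a higher number a weaker inhibitor:
- compound 1 `Cc1cc(Nc2cc(-c3ccccc3)[nH]n2)n2nc(SCc3c(Cl)cccc3Cl)nc2n1`: 5280 nM
- compound 2 `Cc1cc(Nc2cc(-c3ccccc3)[nH]n2)n2nc(SCc3ccc(Br)cc3)nc2n1`: 1110 nM
- compound 3 `Cc1cc(Nc2cc(-c3ccccc3)[nH]n2)n2nc(SCc3cccc(Br)c3)nc2n1`: 4820 nM

Compound 3 belongs to the upper pair of these three numbers, and the gap within that pair is small: a 1.1-fold lower number from compound 1 to compound 3 (0.04 log units; within the scatter). The remaining compound lies clearly apart: a 4.3-fold higher number from compound 2 to compound 3 (0.64 log units; beyond the scatter).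

The next change gives compound 4 `C=CCSc1nc2nc(C)cc(Nc3cc(-c4ccccc4)[nH]n3)n2n1`: vinyl in place of 3-bromophenyl on a saturated chain carbon bound to a sulfur. This is vinyl in place of 3-bromophenyl on a saturated chain carbon bound to a sulfur, or 3-bromobenzyl to allyl.

Among the measured compounds shown here, the steps that bear on it alter the group at that same carbon: a 4.8-fold lower number from compound 1 to compound 2 (0.68 log units; beyond the scatter) and a 1.1-fold lower number from compound 1 to compound 3 (0.04 log units; within the scatter). All of them keep a benzene ring, so none measures its removal, and they guide size more than direction. Compound 4 has no 4-bromophenyl, so nothing suggests it will match compound 2 at 1110 nM.

The expected step is small and leans upward: a 1.2-fold higher number from compound 3 to compound 4 (0.10 log units; within the scatter).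

For compound 4 the estimated value in this assay is 6000 nM, with an expected range of 2000 nM to 18000 nM.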

Compound 4, half-maximal inhibitory concentration: 17200 nM
For compound 4 the middle estimate is 2.9-fold (0.46 log units) below the measured one, and the stated range covers the measured number.
By their numbers in this assay, from the lowest: compound 2; then compounds 3 and 1 (each within the scatter of the next); then compound 4.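

In this assay, among the compounds shown here, the step of a 3.6-fold higher number from compound 3 to compound 4 (0.55 log units; beyond the scatter) is the first measure of losing the benzene ring at this carbon, and a 3.3-fold higher number from compound 1 to compound 4 (0.51 log units; beyond the scatter) points the same way even though the 2,6-dichlorophenyl and 3-bromophenyl groups sit within the scatter of each other. The widest gap is a 15-fold higher number from compound 2 to compound 4 (1.19 log units; beyond the scatter) and it shows that all three halogenated benzene rings on this carbon give lower numbers than vinyl, with none of the four compounds going against that order. No measured evidence accounts for this loss.

The compounds shown leave open whether the lower numbers follow from the benzene ring alone or need its halogens, and an unsubstituted benzyl group would bear on this. From the compounds shown here alone, how a longer saturated chain or a chain ending in an amine compares with allyl also stays open.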